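Methoxy for methyl on the sulfonyl aryl ring

The compounds below may be only part of what the source reports. "The series", "measured", "known", "first", "only" and "open" are said of these compounds alone.

Compound 1 `COc1ccc(Nc2ccnc(Nc3ccc(NS(=O)(=O)c4ccc(OC)cc4)cc3)n2)cc1`: 6870 nM
Compound 2 `COc1ccc(Nc2ccnc(Nc3ccc(NS(=O)(=O)c4ccc(C)cc4)cc3)n2)cc1`: 21200 nM
Compound 3 `COc1cc(Nc2ccnc(Nc3ccc(NS(=O)(=O)c4ccc(C)cc4)cc3)n2)cc(OC)c1OC`: 17300 nM

Of the compounds shown here, three have been tested in a functional assay on MDA-MB-231 cells (Homo sapiens) for antiproliferative activity, read by MTT assay; a lower number here means a stronger inhibitor, a higher number a weaker inhibitor. Compound 1 gives 6870 nM, compound 2 gives 21200 nM and compound 3 gives 17300 nM. Compound 3 holds the second highest of the three numbers; its step to compound 2 is within the scatter, while compound 1 sits well apart with a lower number.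

Compound 4 `COc1ccc(S(=O)(=O)Nc2ccc(Nc3nccc(Nc4cc(OC)c(OC)c(OC)c4)n3)cc2)cc1` has not been measured. It differs from compound 3 by methoxy in place of methyl on an aromatic carbon. Among the compounds with values here, the one measured step that bears on this change is the reverse one: a 3.1-fold higher number from compound 1 to compound 2 (0.49 log units; beyond the scatter). The change from compound 2 to compound 3 was a 1.2-fold lower number from compound 2 to compound 3 (0.09 log units; within the scatter), so the other end of the molecule appears to leave this exchange largely untouched. A step of similar size in the opposite direction is therefore expected, namely a 3.1-fold lower number from compound 3 to compound 4 (0.49 log units; beyond the scatter). Compound 4 is estimated at 5600 nM, with a range from 2500 nM to 12500 nM.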

Compound 4, half-maximal inhibitory concentration: 5990 nM
Compound 4: the middle estimate sits 1.1-fold (0.03 log units) below what was measured; measured number inside the range.
By their numbers in this assay, from the lowest: compounds 4 and 1 (each within the scatter of the next); then compounds 3 and 2 (each within the scatter of the next).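

In this assay, the change from (4-methylphenyl)sulfonyl to (4-methoxyphenyl)sulfonyl can now be read directly with the 3,4,5-trimethoxyphenyl group in place, a 2.9-fold lower number from compound 3 to compound 4 (0.46 log units; beyond the scatter), and the step keeps its direction and size on both cores: the same change on two cores in this assay, a 3.1-fold higher number (0.49 log units; beyond the scatter) from compound 1 to compound 2 and a 2.9-fold higher number (0.46 log units; beyond the scatter) from compound 4 to compound 3, 1.1-fold (0.03 log units) apart, within the scatter of two such steps. The exchange of 4-methoxyphenyl for 3,4,5-trimethoxyphenyl on the nitrogen, now read with methoxy at the other end, again stays small, a 1.1-fold lower number from compound 1 to compound 4 (0.06 log units; within the scatter), matching what it did with methyl there: the same change on two cores in this assay, a 1.2-fold lower number (0.09 log units; within the scatter) from compound 2 to compound 3 and a 1.1-fold lower number (0.06 log units; within the scatter) from compound 1 to compound 4, 1.1-fold (0.03 log units) apart, within the scatter of two such steps. Across these four compounds, none goes against the reading that each of the two changes keeps its effect whichever group stands at the other end.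

Among the compounds shown, this position carries only methyl or methoxy, so how an ethoxy group, a chlorine atom or an amine would read there stays open. What underlies the step also remains unresolved.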